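The source may hold more compounds than are shown below. What is called first, only, known or untested is meant among the compounds shown, and "the series" means these compounds.

In a functional assay on MCF7 cells (Homo sapiens) for antiproliferative activity, read by MTT assay (on this read-out higher numbers stand for weaker inhibition and lower numbers for stronger inhibition), compound 1 `CC1(C)CCc2cc(C(=O)/C=C/c3ccc(OCc4cn(-c5ccc(Br)cc5)nn4)cc3)c(O)cc2O1` is recorded as "not active" (no number reported), so it offers a qualitative starting point but no number to measure a change from. Compound 4 `CCCCCCCCn1cc(COc2ccc(/C=C/C(=O)c3cc4c(cc3O)OC(C)(C)CC4)cc2)nn1` shares the core of compound 1 and differs in a single place: octyl in place of 4-bromophenyl on an aromatic nitrogen. In this change a ring gives way to a chain with no ring.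

The nearest numbers come from two relatives, compound 2 `COc1ccc(-n2cc(COc3ccc(/C=C/C(=O)c4ccc5c(c4O)CCC(C)(C)O5)cc3)nn2)c([N+](=O)[O-])c1` and compound 3 `CC(=O)c1ccc(-n2cc(COc3ccc(/C=C/C(=O)c4ccc5c(c4O)CCC(C)(C)O5)cc3)nn2)cc1`. Compound 2 gives 73100 nM, and compound 3 gives 171000 nM. Within the data shown here, the only measured step is a 2.3-fold higher number from compound 2 to compound 3 (0.37 log units; beyond the scatter). It is a modest change, but it swaps one substituted phenyl group for another, and neither compound carries an octyl group. Both also have a core that is not quite that of compound 1, so this step is only a loose guide.

With no number for compound 1, no size can be stated for the step to compound 4. The direction expected is a shift from no measurable inhibition to weak but measurable inhibition, though another inactive result remains quite possible. For compound 4, the expected value is 50000 nM, with an estimated range from 10000 nM to 200000 nM.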

Compound 4, half-maximal inhibitory concentration: "not active" (no number reported)
Compound 4: no number reported; the estimate stays without a comparison.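

In this assay, among these compounds, compound 1 gives "not active" (no number reported) and compound 4 gives "not active" (no number reported), so no step between them can be read. The compounds shown leave open whether octyl in place of 4-bromophenyl changes activity at all in this assay. No supporting evidence bears on this result.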